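Chloro for methoxy on a porcupine inhibitor scaffold

This account rests on a few compounds, and the source may have more. Where it says the series, first, only, none or still open, it means among the compounds named here.

Compound 1: `COc1ccc2nc(NC(=O)CSc3nc4c(c(=O)n3-c3ccccc3)SCC4)sc2c1` — 40 nM
Compound 2: `COc1ccccc1-n1c(SCC(=O)Nc2nc3ccc(C)cc3s2)nc2c(c1=O)SCC2` — 25 nM
Compound 3: `CCOC(=O)c1ccc(NC(=O)CSc2nc3c(c(=O)n2-c2ccccc2)SCC3)cc1` — 300 nM

Of the compounds shown here, three built on a shared core have been measured in an assay on L cells for inhibition of Protein-serine O-palmitoleoyltransferase porcupine (Mus musculus), read by reporter gene assay, with a stated time of 24 h; on this read-out higher numbers stand for an effect only at larger amounts of compound and lower numbers for an effect already at smaller amounts. Compound 1 gives 40 nM, the second highest of the three numbers. Its nearest neighbour is compound 2, whose 25 nM lies within the usual scatter of repeated measurements relative to compound 1, so no order between the two can be claimed. Compound 3, with 300 nM, stands furthest from compound 1, and that gap lies beyond the scatter.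

The as yet unmeasured compound 4 `O=C(CSc1nc2c(c(=O)n1-c1ccccc1)SCC2)Nc1nc2ccc(Cl)cc2s1` is derived from compound 1 by a single change: chloro in place of methoxy on an aromatic carbon. Going by the values given here, no pair of measured compounds isolates this particular change, so its effect in this assay cannot be read off directly. Given that a small group is exchanged for another small group and that the rest of the molecule is untouched, the expected step from compound 1 to compound 4 is a modest one, with no direction firmly favoured, and most likely within the scatter.

Compound 4 is therefore expected to give about 35 nM in this assay, with a range from 12 nM to 110 nM. This estimate corresponds to an expected step of a 1.1-fold lower number from compound 1 to compound 4 (0.06 log units; within the scatter), which would be within the scatter.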

Compound 4, half-maximal effective concentration: 40 nM
Compound 4: middle estimate off by 1.1-fold (0.06 log units), on the low side, within the range that was stated.
By their numbers in this assay, from the lowest: compounds 2, 1 and 4 (each within the scatter of the next); then compound 3.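

In this assay, chloro in place of methoxy on this aromatic carbon, meta to a fused ring and para to a fused ring, gives no change at the digits printed from compound 1 to compound 4 (within the scatter), the first step shown that isolates a single place on the shared core. Methoxy counts 2 heavy atoms and 1 hydrogen-bond acceptor, while chloro counts 1 heavy atom and 0 hydrogen-bond acceptors, so in this pair the read-out does not depend on the methoxy oxygen or its acceptor, and the position accepts either group. No measurement is available that explains why the two groups read alike here.

From the compounds shown here alone, the result covers only these two small groups, so it remains open how an amine, a carboxylic acid or a longer chain such as butoxy would read on the same aromatic carbon. It is also open whether chloro and methoxy would read alike with a different group on the ring at the other end of the core, since this exchange is shown in one setting only.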